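A few compounds are considered here, and "the series" means these few. Any claim that something is new, unique, unknown or untested is made for them only; others in the source may bear on it.

Compound 3 `CCN(CC)S(=O)(=O)c1ccc(S(=O)(=O)N2CCC[C@@H](C(=O)N3CC[C@@H](OC)C3)C2)cc1` is the last of three compounds that share one core and are tested in a functional assay on MIA PaCa-2 cells (Homo sapiens) for inhibition, read by MTT assay, with a stated time of 3 days; a lower number here means a stronger inhibitor, a higher number a weaker inhibitor. In this assay compound 3 gives only a limit, > 10000 nM. Compound 1 `CCN(CC)S(=O)(=O)c1ccc(S(=O)(=O)N2CCC[C@@H](C(=O)NC3CCOCC3)C2)cc1` likewise sits at a limit in this assay, > 10000 nM. Compound 2 `CCN(CC)S(=O)(=O)c1ccc(S(=O)(=O)N2CCC[C@@H](C(=O)N[C@H]3CCOC3)C2)cc1` also reaches only a limit there, > 10000 nM. The steps among them, a step that the two limits leave unreadable from compound 1 to compound 2, a step that the two limits leave unreadable from compound 1 to compound 3 and a step that the two limits leave unreadable from compound 2 to compound 3, cannot be read in size because of the limit of > 10000 nM in this assay, at which 3 of the 3 values shown sit. Compound 4 `CCN(CC)S(=O)(=O)c1ccc(S(=O)(=O)N2CCC[C@@H](C(=O)N3CCC(C(F)F)CC3)C2)cc1` differs from compound 3 in one place: 4-(difluoromethyl)piperidin-1-yl in place of 3-methoxypyrrolidin-1-yl on a carbonyl carbon. Going by the values given here, none of the measured steps shows a readable change on this side of the core, and each of the three values stops at the same limit, so there is no measured direction to carry over. Compound 4 is therefore expected to stay near that limit, with the step that the limit leaves unreadable from compound 3 to compound 4 expected to be small or none beyond the scatter. Compound 4 is estimated in this assay at 15000 nM, within a range from 4000 nM to 60000 nM.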

Compound 4, half-maximal inhibitory concentration: > 10000 nM
Compound 4 was reported as a limit (the forecaster's own chance of this, stated with the estimate: 80%); the middle value lies beyond the limit too.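

Compound 4 joins compound 1, compound 2 and compound 3 in this assay, and no step among these compounds can be read, because all of them stop at one limit: the limit of > 10000 nM in this assay, at which 4 of the 4 values shown sit. The compounds shown leave open whether the groups on the carbonyl carbon differ at all in strength of inhibition.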